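Phenoxy Replaces Acetamido at the Assay Limit

The compounds below may be only part of what the source reports. "The series", "measured", "known", "first", "only" and "open" are said of these compounds alone.

Compound 1 `O=S(=O)(NC1=NCCN1C(=S)SN1CCn2c1nsc2=S)c1ccccc1` gives >= 20000 nM in a functional assay on KYSE-510 cells (Homo sapiens) for antiproliferative activity, read by crystal violet staining, with a stated time of 96 h (a higher number here means a weaker inhibitor of growth, a lower number a stronger inhibitor of growth), a limit of the assay.
Compound 2 `CC(=O)Nc1ccc(S(=O)(=O)NC2=NCCN2C(=S)SN2CCn3c2nsc3=S)cc1` gives >= 20000 nM in this assay, again a limit of the assay.

Among the measured compounds shown here, compound 2 therefore stands at the limit, as does the one other measured compound. The step that the two limits leave unreadable from compound 1 to compound 2 cannot be read because both values sit at the limit of >= 20000 nM in this assay, at which 2 of the 2 values shown sit. Compound 3 `O=S(=O)(NC1=NCCN1C(=S)SN1CCn2c1nsc2=S)c1ccc(Oc2ccccc2)cc1` differs from compound 2 by phenoxy in place of acetamido on an aromatic carbon. For the measured compounds named here, no readable step bears on this change: the only measured step is unreadable, and neither measured value is a number. The expectation for compound 3 in this assay is thus that it again reaches only the limit, and compound 3 is estimated at 20000 nM, with a range from 5000 nM to 60000 nM. The step from compound 2 to compound 3 is expected to be a number no higher from compound 2 to compound 3 (the limit leaves the size open), no change beyond the scatter.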

Compound 3, concentration for 50% growth inhibition: >= 20000 nM
Compound 3: a limit, no number; the forecaster's own chance of this, stated with the estimate: 85%; the middle value lies on the limit itself.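

Among the compounds shown here, no step among compound 1, compound 2 and compound 3 can be read in this assay, because all three values are limits of the assay: the limit of >= 20000 nM in this assay, at which 3 of the 3 values shown sit.

The compounds shown leave open how strongly each one inhibits growth, and whether acetamido or phenoxy on the aromatic ring changes that at all.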